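The compounds below may be only part of what the source reports. "The series", "measured", "known", "first", "only" and "open" are said of these compounds alone.

Compound 1 `Cc1nc(-c2ccc(C(F)(F)F)cc2)sc1CNc1ccc(CCC(=O)O)cc1` is measured in a functional assay on CHO cells for agonist activity at Free fatty acid receptor 1 (Homo sapiens) (a higher number here means that more compound is needed for the effect, a lower number that less compound is needed), at 67.6 nM; of the three numbers in hand this is the lowest, yet it sits within the scatter of both others. Compound 2 `CC(CC(=O)O)c1ccc(NCc2cccc(Oc3ccccc3)c2)cc1` gives 126 nM and compound 3 `O=C(CCc1ccc(NCc2cccc(Oc3ccccc3)c2)cc1)N1CCCC1` gives 115 nM. Among the compounds with values here, the one step that can be set apart, a 1.1-fold lower number from compound 2 to compound 3 (0.04 log units; within the scatter), exchanges the carboxylic acid end for a pyrrolidine amide without any shift beyond the scatter.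

Compound 4 `Cc1nc(-c2ccc(C(F)(F)F)cc2)sc1CNc1ccc([C@H]2C[C@@H]2C(=O)N(C)C)cc1` has not yet been measured. Relative to compound 1 the change is 2-(dimethylcarbamoyl)cyclopropyl in place of 2-carboxyethyl on an aromatic carbon. Within the data shown here, the acid of compound 1 is again replaced by a tertiary amide, the part of the change that the single measured step speaks to, and that step stayed within the scatter. Among the measured compounds shown here, the cyclopropyl in place of the two-carbon chain has no counterpart among the measured compounds, so nothing in hand argues for a shift either way. For compound 4 no step beyond the scatter is therefore expected, a 1.2-fold higher number from compound 1 to compound 4 (0.07 log units; within the scatter). Compound 4 is estimated at 80 nM, within a range from 30 nM to 250 nM.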

Compound 4, half-maximal effective concentration: 66.1 nM
For compound 4 the middle estimate is 1.2-fold (0.08 log units) above the measured one, and the stated range covers the measured number.
By their numbers in this assay, from the lowest: compounds 4, 1, 3 and 2 (each within the scatter of the next).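

In this assay, 2-(dimethylcarbamoyl)cyclopropyl on the aromatic carbon para to a large group stands in for 2-carboxyethyl on the core of compound 1 with no shift beyond the scatter: a 1.0-fold lower number from compound 1 to compound 4 (0.01 log units; within the scatter). The earlier exchange of an acid for a tertiary amide was read only on another core and without a three-membered ring, whereas here the amide, the ring and the defined stereocentres enter together, and this place accepts a group without a hydrogen-bond donor. No supporting evidence bears on why the number holds.

As far as these compounds go, what a 2-carboxycyclopropyl group or a 2-(dimethylcarbamoyl)ethyl group would give on this core stays open, so the shares of ring and amide remain unseparated. Also open, from the compounds shown here alone, are the opposite stereoisomer of the cyclopropyl group, a primary amide and a longer chain at this place.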